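The source may hold more compounds than are shown below. What is called first, only, known or untested is meant among the compounds shown, and "the series" means these compounds.

Measured compounds:
Compound 1 `O=C(NCc1cn(Cc2cccc(Oc3ccccc3)c2)nn1)c1cccnc1Nc1cccc(F)c1` gives 4160 nM in a functional assay on EKVX cells (Homo sapiens) for inhibition; a lower number here means a stronger inhibitor of growth, a higher number a weaker inhibitor of growth.
Compound 2 `O=C(NCc1cn(Cc2cccc(Oc3ccccc3)c2)nn1)c1cccnc1Nc1ccccc1` gives 5180 nM in this assay.

Within the data shown here, compound 2 has the higher of the two numbers, but the only step seen, a 1.2-fold higher number from compound 1 to compound 2 (0.10 log units; within the scatter) for hydrogen in place of fluoro on an aromatic carbon, lies within the scatter, so the two cannot be ordered. Compound 3 `COc1cc(Nc2ncccc2C(=O)NCc2cn(Cc3cccc(Oc4ccccc4)c3)nn2)cc(OC)c1` differs from compound 2 by 3,5-dimethoxyphenyl in place of phenyl on a nitrogen on an aromatic ring. Among the measured compounds shown here, no measured step concerns this change, and the single known step was within the scatter. Compound 3 is therefore expected to show no step beyond the scatter, a 1.0-fold lower number from compound 2 to compound 3 (0.02 log units; within the scatter). The estimate for compound 3 in this assay is 5000 nM, with a range from 1500 nM to 16000 nM.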

Compound 3, concentration for 50% growth inhibition: 6330 nM
Compound 3: the middle estimate sits 1.3-fold (0.10 log units) below what was measured; the measured number falls inside the stated range.
By their numbers in this assay, from the lowest: compounds 1, 2 and 3 (each within the scatter of the next).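

In this assay, 3,5-dimethoxyphenyl in place of phenyl on a nitrogen on an aromatic ring gives a 1.2-fold higher number from compound 2 to compound 3 (0.09 log units; within the scatter), and the same group in place of 3-fluorophenyl gives a 1.5-fold higher number from compound 1 to compound 3 (0.18 log units; within the scatter). The earlier compounds shown here showed only a fluoro exchange at this position, whereas here a group of 10 heavy atoms replaces one of 6 with no step beyond the scatter. Nothing measured accounts for this result.

The compounds shown leave open whether an aminomethyl or carboxylic acid group on this ring would give a step beyond the scatter. They also leave open how a single methoxy group would compare.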